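This account rests on a few compounds, and the source may have more. Where it says the series, first, only, none or still open, it means among the compounds named here.

Measured compounds:
compound 1, `Cc1ccc(Cn2c(/C=C3\SC(=S)N(CC(=O)O)C3=O)nc3cc(F)ccc32)cc1`, 6550 nM;
compound 2, `Cc1ccc(Cn2c(/C=C3\SC(=S)N(CC(=O)O)C3=O)nc3ccc(F)cc32)cc1`, 3860 nM;
compound 3, `COc1ccc2c(c1)nc(/C=C1\SC(=S)N(CC(=O)O)C1=O)n2Cc1ccc(C)cc1`, 1220 nM.

Compound 1 and compound 2 share the same atoms joined differently; the difference between the two cores is not broken down here. Their two values in a functional assay on MDA-MB-231 cells (Homo sapiens) for cytotoxicity, read by MTT assay, with a stated time of 48 h (a lower number here means a stronger inhibitor, a higher number a weaker inhibitor), lie within the scatter of each other. Compound 3 arises from compound 1 by methoxy in place of fluoro on an aromatic carbon, and this gave a 5.4-fold lower number from compound 1 to compound 3 (0.73 log units; beyond the scatter). Compound 4, `COc1ccc2nc(/C=C3\SC(=S)N(CC(=O)O)C3=O)n(Cc3ccc(C)cc3)c2c1`, is not yet measured; it arises from compound 2 by methoxy in place of fluoro on an aromatic carbon, the same change, since the place described is the same in both cases. For compound 4 in this assay a step of about a 3.9-fold lower number from compound 2 to compound 4 (0.59 log units; beyond the scatter) is expected, resting on the single earlier case, where compound 1 gave a 5.4-fold lower number from compound 1 to compound 3 (0.73 log units; beyond the scatter). Compound 4 is therefore estimated at 1000 nM, expected to fall between 400 nM and 2500 nM.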

Compound 4, half-maximal inhibitory concentration: 3770 nM
Compound 4: middle estimate off by 3.8-fold (0.58 log units), on the low side, outside the stated range (above it).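

Methoxy in place of fluoro on an aromatic carbon gave a 1.0-fold lower number from compound 2 to compound 4 (0.01 log units; within the scatter) on the core of compound 2, so no gain can be claimed for that core. In this assay the change therefore does not carry over at one size between these two cores: the same change on two cores in this assay, a 5.4-fold lower number (0.73 log units; beyond the scatter) from compound 1 to compound 3 and a 1.0-fold lower number (0.01 log units; within the scatter) from compound 2 to compound 4, 5.2-fold (0.72 log units) apart, beyond the scatter of two such steps. This shows that, for these two pairs, the outcome depends on the core, but it does not show what underlies the difference, and two pairs give no rule for other cores.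

Only fluoro and methoxy are shown at this place on the two cores. On these data alone, whether chloro, hydroxyl or an amine there would follow the pattern of compound 1 and compound 3 or that of compound 2 and compound 4 remains open.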